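This account rests on a few compounds, and the source may have more. Where it says the series, first, only, none or still open, it means among the compounds named here.

Measured in a functional assay on CEM-DNR-bulk cells (Homo sapiens), read by MTT assay, with a stated time of 72 h; a lower number here means a stronger inhibitor, a higher number a weaker inhibitor:
- Compound 1 `COc1ncnc2c1c(-c1cc3ccccc3o1)cn2[C@@H]1O[C@H](CO)[C@@H](O)[C@H]1O`: 10800 nM
- Compound 2 `CNc1ncnc2c1c(-c1ccsc1)cn2[C@@H]1O[C@H](CO)[C@@H](O)[C@H]1O`: > 20000 nM (a limit, not a number)
- Compound 3 `O=c1[nH]cnc2c1c(-c1ccccc1)cn2[C@@H]1O[C@H](CO)[C@@H](O)[C@H]1O`: > 20000 nM (a limit, not a number)

Compound 3 has no number, and its reading is only a limit. Compound 3 sits on (the limit of > 20000 nM in this assay, at which 2 of the 3 values shown sit). Its true position in this assay is therefore open, and any step away from it can be judged only against that limit.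

The next compound to be read is compound 4 `O=c1[nH]cnc2c1c(-c1cc3ccccc3o1)cn2[C@@H]1O[C@H](CO)[C@@H](O)[C@H]1O`, which carries 1-benzofuran-2-yl in place of phenyl on an aromatic carbon. Going by the values given here, no step between measured compounds is available to size this change directly.

Among the compounds with values here, the nearest guide is compound 1, the only measured compound with 1-benzofuran-2-yl and the only one with a number, at 10800 nM. This is a single compound, so the support is thin. A small step toward stronger inhibition is expected in this assay, and a reading that stays at the limit would be no surprise.

The expected change is an at least 1.2-fold lower number from compound 3 to compound 4 (0.09 log units; that floor lies within the scatter), an estimate that is uncertain in size. For compound 4 the estimated value is 16000 nM, with an expected range of 6000 nM to 40000 nM.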

Compound 4, half-maximal inhibitory concentration: > 20000 nM
Compound 4 gave a limit, no number; the forecaster's own chance of this, stated with the estimate: 55%; middle value at least 1.2-fold (0.09 log units) from the limit.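

Compound 3 and compound 4 both stand only as limits in this assay, so no step can be read between them. The position they share is this: the limit of > 20000 nM in this assay, at which 3 of the 4 values shown sit. Left open is whether 1-benzofuran-2-yl in place of phenyl on an aromatic carbon changes the reading at all, and where either compound truly lies.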